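The source may hold more compounds than are shown below. What is called first, only, known or untested is meant among the compounds shown, and "the series" means these compounds.

Compound 1: `O=C(Nc1ccc(F)c(C(F)(F)F)c1)Nc1ccccn1`, giving 1.6 ug/mL in a physicochemical assay for solubility, read by nephelometry, measured as kinetic solubility, at pH 2; on this read-out lower numbers stand for lower solubility and higher numbers for higher solubility.
Compound 2: `CC(=O)c1ccc(NC(=O)Nc2ccc(F)c(C(F)(F)F)c2)cc1`, reported in this assay only as the limit < 1.6 ug/mL.

Compound 2 therefore stands at the low end of the two results: its reading is a limit of the assay and not a number, as stated by the limit of < 1.6 ug/mL in this assay, at which 1 of the 2 values shown sits. Compound 1 sits just at that same figure as a measured value, so the two compounds cannot be ordered against each other. The next compound, compound 3 `NC(=O)c1ccc(NC(=O)Nc2ccc(F)c(C(F)(F)F)c2)cc1`, differs from compound 2 in a single place: amino in place of methyl on a carbonyl carbon. Among the measured compounds shown here, no measured pair in this set shares that change, so the size of the step cannot be read from the data. The step from compound 2 to compound 3 is expected to be an at least 1.8-fold higher number from compound 2 to compound 3 (0.27 log units; that floor lies within the scatter), a small rise that may or may not reach beyond the scatter. Compound 3 is estimated to give 3 ug/mL in this assay, within a range from 1 ug/mL to 12 ug/mL.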

Compound 3, solubility: 6.3 ug/mL
Estimate against measurement, compound 3: 2.1-fold (0.32 log units) below, and the stated range covers the measured number.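

Among the compounds shown here, on a carbonyl carbon whose other neighbour is an aromatic carbon, amino in place of methyl comes out as an at least 3.9-fold higher number from compound 2 to compound 3 (0.59 log units; beyond the scatter) in this assay, the first step in this set that can be read and one that lies beyond the scatter. The change swaps a single heavy atom, turning acetyl into carbamoyl and adding one hydrogen-bond donor, and the rest of the structure stays the same. Compound 2 stands only as a limit of the assay, so the step is known as a floor and not as a full size: the limit of < 1.6 ug/mL in this assay, at which 1 of the 3 values shown sits.

As far as these compounds go, how far the rise extends stays open, and a single pair cannot show whether it would hold on another core. Also open, from the compounds shown here alone, is what a carboxylic acid, a methylamino group or a dimethylamino group would give on the same carbonyl carbon.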